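Aryl-thioether variation in a shared core series

The source may report more compounds than this note shows. Statements on the series, on what has been measured and on what is new or still open speak of the compounds shown alone.

Measured compounds:
compound 1 `Cc1cc(N2CC[C@@H](C)[C@@H](N(C)c3ncnc4[nH]ccc34)C2)n2nc(SCC3CC3)nc2n1`, 21400 nM
compound 2 `Cc1cc(N2CC[C@@H](C)[C@@H](N(C)c3ncnc4[nH]ccc34)C2)n2nc(SCc3cc(Cl)ccc3Cl)nc2n1`, 19200 nM
compound 3 `Cc1cc(N2CC[C@@H](C)[C@@H](N(C)c3ncnc4[nH]ccc34)C2)n2nc(SCCc3ccccc3)nc2n1`, 11800 nM

In a functional assay on HGC-27 cells (Homo sapiens) for inhibition, read by MTT assay, with a stated time of 72 h (on this read-out higher numbers stand for weaker inhibition and lower numbers for stronger inhibition), compound 1 gives 21400 nM, compound 2 gives 19200 nM and compound 3 gives 11800 nM. Compound 3 carries the lowest number of the three, but every step separating it from the others sits within the scatter: a 1.8-fold lower number from compound 1 to compound 3 (0.26 log units; within the scatter) and a 1.6-fold lower number from compound 2 to compound 3 (0.21 log units; within the scatter). The three measured compounds are therefore indistinguishable on this assay.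

Compound 4 `Cc1cc(N2CC[C@@H](C)[C@@H](N(C)c3ncnc4[nH]ccc34)C2)n2nc(SCc3ccc(F)c(Cl)c3)nc2n1` differs from compound 3 at the sulfur-bound chain carbon: 3-chloro-4-fluorophenyl in place of benzyl on a saturated chain carbon bound to a sulfur. Going by the values given here, the only measured step bearing on it is the one between compound 2 and compound 3, which also exchanges a halogenated phenyl for benzyl at the same place and reads a 1.6-fold lower number from compound 2 to compound 3 (0.21 log units; within the scatter). Since that exchange stayed within the scatter, and so did a 1.1-fold lower number from compound 1 to compound 2 (0.05 log units; within the scatter) when a halogenated phenyl replaced cyclopropyl, no step beyond the scatter is expected in this assay for compound 4; the step to compound 4 is estimated as a 1.2-fold higher number from compound 3 to compound 4 (0.07 log units; within the scatter). Compound 4 is accordingly expected to give about 14000 nM, with a range from 6000 nM to 35000 nM.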

Compound 4, half-maximal inhibitory concentration: > 100000 nM
Compound 4: no number, only a limit (the forecaster's own chance of this, stated with the estimate: 5%); at least 7.1-fold (0.85 log units) between middle value and limit.
By their numbers in this assay, from the lowest: compounds 3, 2 and 1 (each within the scatter of the next). At a limit, above all of these: compound 4.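

At the saturated chain carbon bound to a sulfur, cyclopropyl, 2,5-dichlorophenyl and benzyl had given readings within the scatter of one another in this assay, whereas 3-chloro-4-fluorophenyl separates from all three: an at least 8.4-fold higher number from compound 3 to compound 4 (0.92 log units; beyond the scatter), an at least 5.2-fold higher number from compound 2 to compound 4 (0.71 log units; beyond the scatter) and an at least 4.6-fold higher number from compound 1 to compound 4 (0.66 log units; beyond the scatter). The step from compound 2 matters most, since both compounds carry a halogenated phenyl at this place, so the presence of a halogenated phenyl does not by itself set the reading; which halogens the ring carries, and where, does make a difference here. The reading of compound 4 is a limit of the assay and not a number, so the true size of these steps stays undetermined: the limit of > 100000 nM in this assay, at which 1 of the 4 values shown sits.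

With a single compound at this limit, no rule on halogen pattern can be drawn from the series. As far as these compounds go, it also remains open whether chlorine or fluorine alone on the phenyl ring would give the same result, and how an amine, a carboxylic acid or a longer chain at this place would read.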